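Working notes: 4-hydroxycyclohexyl on the amide-type nitrogen

This account rests on a few compounds, and the source may have more. Where it says the series, first, only, none or still open, it means among the compounds named here.

Measured so far in an ADME assay for protein binding, using equilibrium dialysis, at pH 7.4, tested at 2 uM; on this read-out higher numbers stand for a larger free fraction and lower numbers for a smaller free fraction:
- compound 1 `CC(C)(C)C#Cc1cc(N(C(=O)[C@H]2CC[C@H](C)CC2)[C@H]2CC[C@H](Oc3cccnc3)CC2)c(C(=O)O)s1` gives 0.03
- compound 2 `CC(C)(C)C#Cc1cc(N(CCO)C(=O)[C@H]2CC[C@H](C)CC2)c(C(=O)O)s1` gives "not determined" (no result reported)

Within the data shown here, compound 2 has no number to stand on, as its entry reads "not determined" (no result reported) and no step can be sized from it. The structural change is 4-hydroxycyclohexyl in place of 2-hydroxyethyl on an amide-type nitrogen and it sets 4-hydroxycyclohexyl in place of 2-hydroxyethyl on an amide-type nitrogen. The result, compound 3 `CC(C)(C)C#Cc1cc(N(C(=O)[C@H]2CC[C@H](C)CC2)[C@H]2CC[C@H](O)CC2)c(C(=O)O)s1`, is still unmeasured. Among the measured compounds shown here, the only number available is that of compound 1 at 0.03 and from it a small upward difference, within the usual scatter, is expected. The estimate for compound 3 is 0.04 with an expected range from 0.015 to 0.1.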

Compound 3, unbound fraction: 0.19
Compound 3: middle estimate off by 4.8-fold (0.68 log units), on the low side; the measured number lies above the stated range.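

In this assay, hydrogen in place of pyridin-3-yl on the oxygen on a saturated carbon gives a 6.3-fold higher number from compound 1 to compound 3 (0.80 log units; beyond the scatter), a step beyond the scatter, so the substituent on this oxygen does shift the read-out. The step between 2-hydroxyethyl and 4-hydroxycyclohexyl on the amide-type nitrogen cannot be read, as compound 2 has no number. Nothing on hand accounts for the size of the step.

Open, going by these compounds, is how an amine or a methoxy group in place of the hydroxyl of the 4-hydroxycyclohexyl would read in this assay. Also open, on these data alone, is how a carboxylic acid on that oxygen-bearing carbon would compare.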